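Diethylamino for piperidin-1-yl in the series

The compounds below may be only part of what the source reports. "The series", "measured", "known", "first", "only" and "open" are said of these compounds alone.

Within the data shown here, in a functional assay on the whole organism for antagonist activity, with Rattus norvegicus as the target (on this read-out higher numbers stand for an effect only at larger amounts of compound and lower numbers for an effect already at smaller amounts), compound 2 `O=C(Nc1ccc(C(=O)N2CCCCc3sccc32)cc1OCCCC(=O)N1CCC(N2CCCCC2)CC1)c1ccccc1-c1ccccc1` gives 0.03 mg/kg as the higher of only two numbers so far, and compound 1 `CN(C)C1CCN(C(=O)CCCOc2cc(C(=O)N3CCCCc4sccc43)ccc2NC(=O)c2ccccc2-c2ccccc2)CC1` gives 0.005 mg/kg as the lower.

Compound 3 `CCN(CC)C1CCN(C(=O)CCCOc2cc(C(=O)N3CCCCc4sccc43)ccc2NC(=O)c2ccccc2-c2ccccc2)CC1` carries diethylamino in place of the piperidin-1-yl of compound 2 on a saturated ring carbon of the six-membered non-aromatic ring with 1 nitrogen (diethylamino in place of piperidin-1-yl on a saturated ring carbon). The core and the rest of the molecule stay the same.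

Among the measured compounds shown here, only one measured step bears on this change: a 6.0-fold higher number from compound 1 to compound 2 (0.78 log units; beyond the scatter) with piperidin-1-yl in place of dimethylamino at that same ring carbon. Diethylamino has no ring, like dimethylamino, but no measured compound carries it, so the evidence is thin. Part of that step is expected to be given back, not all of it. An estimated 2.5-fold lower number from compound 2 to compound 3 (0.40 log units; beyond the scatter) is expected in this assay as a lower number of modest size that may stay within the scatter. Compound 3 is expected at 0.012 mg/kg (estimated range 0.004 mg/kg to 0.04 mg/kg).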

Compound 3, dose for 50% inhibition: 0.01 mg/kg
Estimate against measurement, compound 3: 1.2-fold (0.08 log units) above, within the range that was stated.
By their numbers in this assay, from the lowest: compounds 1 and 3 (each within the scatter of the next); then compound 2.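

In this assay the open-chain diethylamino group on this saturated ring carbon separates from piperidin-1-yl (a 3.0-fold lower number from compound 2 to compound 3 (0.48 log units; beyond the scatter)), so compound 2 now stands apart from two open-chain amines rather than one. The two open-chain groups themselves show no readable separation (a 2.0-fold higher number from compound 1 to compound 3 (0.30 log units; within the scatter)), which places compound 2 alone at the high end of the numbers among these three compounds, with the change from a ring to an open chain as the one feature that tracks the gap in this small set. Nothing available accounts for this separation.

As far as these compounds go, whether other cyclic amines such as pyrrolidin-1-yl or morpholin-4-yl would group with piperidin-1-yl or with the open-chain amines remains open, as does the reading for a smaller secondary amine such as methylamino. Equally open, from the compounds shown here alone, is whether the same gap between piperidin-1-yl and the open-chain amines persists with a longer chain connecting the 4-substituted piperidin-1-yl amide to the shared core.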